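This account rests on a few compounds, and the source may have more. Where it says the series, first, only, none or still open, it means among the compounds named here.

Compound 1 `ClCc1ccc(Cn2cnc3c(Cl)ncnc32)cc1` gives 12900 nM in a functional assay on A498 cells (Homo sapiens) for cytotoxicity, read by sulforhodamine B assay, with a stated time of 48 h; on this read-out lower numbers stand for stronger inhibition of growth and higher numbers for weaker inhibition of growth. Compound 3 `ClCc1ccc(Cn2cnc3c(Cl)nc(Cl)nc32)cc1` carries chloro in place of hydrogen on an aromatic carbon relative to compound 1. In this assay compound 3 gives 12000 nM; the step of a 1.1-fold lower number from compound 1 to compound 3 (0.03 log units; within the scatter) is recorded as within the scatter. Compound 2 `ClCc1cccc(Cn2cnc3ncnc(Cl)c32)c1` has the same atoms as compound 1 joined differently; the difference between the two cores is not broken down here. In this assay compound 2 gives 18200 nM, and its values against compound 1 and compound 3 are both within the scatter, so the three measured compounds are not separated on this read-out.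

Compound 4 `ClCc1cccc(Cn2cnc3nc(Cl)nc(Cl)c32)c1` is not yet measured. It differs from compound 2 by chloro in place of hydrogen on an aromatic carbon. The place description is the same word for word as that for compound 1 to compound 3, so this is the same change, made here on the core of compound 2. Given a 1.1-fold lower number from compound 1 to compound 3 (0.03 log units; within the scatter), the expected step is a 1.1-fold lower number from compound 2 to compound 4 (0.04 log units; within the scatter), essentially flat, resting on that single measured pair. Compound 4 is therefore estimated at 16500 nM in this assay, with a plausible range from 8000 nM to 33000 nM.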

Compound 4, concentration for 50% growth inhibition: 1510 nM
Compound 4: middle estimate off by 11-fold (1.04 log units), on the high side, outside the stated range (below it).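

In this assay chloro in place of hydrogen on an aromatic carbon gives a 12-fold lower number from compound 2 to compound 4 (1.08 log units; beyond the scatter). The same change therefore does not carry over at one size between these two cores, and a step read on one core gives a poor guide to the other: the same change on two cores in this assay, a 1.1-fold lower number (0.03 log units; within the scatter) from compound 1 to compound 3 and a 12-fold lower number (1.08 log units; beyond the scatter) from compound 2 to compound 4, 11-fold (1.05 log units) apart, beyond the scatter of two such steps. This shows that the size of the step depends on the core in these two pairs, but with one pair per core it does not show which difference between the cores matters, why the steps part, or whether the same split would appear in another cell line.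

The compounds shown leave open whether the low number of compound 4 depends on chloro itself, or whether an amine or a methoxy group on the carbon between two ring nitrogen atoms would give a similar result. They also leave open how the result would change if the chloromethyl group on the benzene ring gave way to a hydroxymethyl or a plain methyl group.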